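Pyrrolidine amide to methyl ester: next step in the series

The compounds below may be only part of what the source reports. "The series", "measured", "known", "first", "only" and "open" are said of these compounds alone.

Measured in a functional assay on A549 cells (Homo sapiens) for cytotoxicity, read by sulforhodamine B assay, with a stated time of 72 h; on this read-out higher numbers stand for weaker inhibition and lower numbers for stronger inhibition:
- compound 1 `Nc1sc(-c2ccc(Cl)cc2)c(-c2ccc(Cl)cc2)c1C(=O)Nc1ccccc1`: 25000 nM
- compound 2 `Nc1sc(-c2ccc(Cl)cc2)c(-c2ccc(Cl)cc2)c1C(=O)N1CCCC1`: 890 nM

Going by the values given here, compound 2, at 890 nM, holds the lower of the two numbers so far in this assay. The next compound is compound 3 `COC(=O)c1c(N)sc(-c2ccc(Cl)cc2)c1-c1ccc(Cl)cc1`, with this change from compound 2: methoxy in place of pyrrolidin-1-yl on a carbonyl carbon. In words, methoxy stands in place of pyrrolidin-1-yl on a carbonyl carbon.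

Among the compounds with values here, one measured step bears on this, at the same carbonyl carbon: a 28-fold lower number from compound 1 to compound 2 (1.45 log units; beyond the scatter). Within the data shown here, it shows that a change here can be large, but no methoxy compound has been measured, so its size transfers only loosely. A moderate move toward weaker inhibition is therefore expected, smaller than that step. The expected change is a 4.5-fold higher number from compound 2 to compound 3 (0.65 log units; beyond the scatter). For compound 3 the estimated value in this assay is 4000 nM, with an expected range of 900 nM to 18000 nM.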

Compound 3, half-maximal inhibitory concentration: 5040 nM
Beside the measured number, compound 3's estimate is 1.3-fold (0.10 log units) below it; low and high end bracket the measured number.
By their numbers in this assay, from the lowest: compound 2; then compound 3; then compound 1.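

In this assay, replacing pyrrolidin-1-yl with methoxy on the carbonyl carbon gives a 5.7-fold higher number from compound 2 to compound 3 (0.75 log units; beyond the scatter) and replacing anilino with methoxy gives a 5.0-fold lower number from compound 1 to compound 3 (0.70 log units; beyond the scatter) at the same place. The amides therefore do not group together at this carbonyl carbon: compound 3, the methoxy compound, falls between compound 2 and compound 1, so the choice of amide group matters here, not merely the presence of an amide. No supporting measurement accounts for this order.

On these data alone, it remains open whether an amide of piperidine or dimethylamine would stay close to compound 2 or move toward compound 1. Also open, as far as these compounds go, is how the free carboxylic acid or an ethoxy ester would compare with compound 3 at this carbonyl carbon.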